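The source may hold more compounds than are shown below. What is called first, only, known or untested is meant among the compounds shown, and "the series" means these compounds.

Compound 1 `Cn1c(CN2CCC(c3ccccc3)CC2)nc2ccccc21` gives 6310 nM in a functional assay on CHO cells for agonist activity at metabotropic glutamate receptor 2 (Homo sapiens), read by FLIPR; a higher number here means that more compound is needed for the effect, a lower number that less compound is needed.
Compound 2 `Cn1c(CN2CCN(c3ccc(Cl)cc3F)CC2)nc2ccccc21` gives 2510 nM in this assay.

Among these two numbers, compound 1 holds the highest; its nearest neighbour is compound 2, whose number is lower by a margin beyond the usual scatter. Compound 3 `Cn1c(CN2CCC(c3ccc(Cl)cc3)CC2)nc2ccccc21` differs from compound 1 by chloro in place of hydrogen on an aromatic carbon, in words chloro in place of hydrogen on an aromatic carbon, para to a large group. Within the data shown here, no pair of measured compounds differs by this change alone, so nothing measured fixes its size in this assay. With compound 2 as the only other measured point, and its value 2510 nM standing lower than that of compound 1, the expected step of a 1.8-fold lower number from compound 1 to compound 3 (0.26 log units; within the scatter) is taken as modest and toward a lower number, close to the scatter. Compound 3 is accordingly estimated at 3500 nM, with a range from 1200 nM to 10000 nM.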

Compound 3, half-maximal effective concentration: 5010 nM
Compound 3: the middle estimate sits 1.4-fold (0.16 log units) below what was measured; low and high end bracket the measured number.
By their numbers in this assay, from the lowest: compounds 2, 3 and 1 (each within the scatter of the next, the first and the last beyond it).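

Among these compounds, the first pair of compounds differing in one place gives the size of this change: in this assay, phenyl to 4-chlorophenyl, with chloro in place of hydrogen on an aromatic carbon, para to a large group, amounts to a 1.3-fold lower number from compound 1 to compound 3 (0.10 log units; within the scatter) and so stays within the scatter. At this position, the added chlorine therefore gives no measurable shift on the core of compound 1. No measured information bears on the reason for this result.

On these data alone, it remains open whether a different group at the same position, such as methoxy, an amine or a carboxylic acid, would give a step beyond the scatter. As far as these compounds go, it is also open whether chloro placed elsewhere on this ring would give a step of similar size.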